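From 4-methyl-1H-imidazol-1-yl to a Larger Aromatic Group

The source may report more compounds than this note shows. Statements on the series, on what has been measured and on what is new or still open speak of the compounds shown alone.

In an ADME assay on a cell-free system (plasma, Rattus norvegicus) for protein binding, compound 1 (`O=C(O)c1cn(Cc2ccc(-n3ccnc3)cc2)c2cccc(F)c2c1=O`) gives 83.8% and compound 2 (`Cc1cn(-c2ccc(Cn3cc(C(=O)O)c(=O)c4c(F)cccc43)cc2)cn1`) gives 88.9% with the two level within the scatter. Compound 3 (`O=C(O)c1cn(Cc2ccc(-n3ccc4ncccc43)cc2)c2cccc(F)c2c1=O`) carries a larger group in place of 4-methyl-1H-imidazol-1-yl on an aromatic carbon (a group of 9 heavy atoms (7 carbon, 2 nitrogen; one five-membered aromatic ring with 1 hetero atom, one six-membered aromatic ring with 1 hetero atom) in place of a group of 6 heavy atoms (4 carbon, 2 nitrogen; one five-membered aromatic ring with 2 hetero atoms), on an aromatic carbon). Only the methyl step (a 1.5-fold lower unbound fraction from compound 1 to compound 2 (0.16 log units; within the scatter)) bears on this change, and it is a much smaller change that stays within the scatter. The expected step (a 1.4-fold lower unbound fraction from compound 2 to compound 3 (0.14 log units; within the scatter)) is a modestly lower unbound fraction, not beyond the scatter. For compound 3 the estimate in this assay is 92% with 84% to 97% as the expected range.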

Compound 3, plasma protein binding: 93%
Compound 3: middle estimate off by 1.1-fold (0.06 log units) (unbound fraction), on the high side; low and high end bracket the measured number.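

In this assay, putting the larger group with a five-membered and a six-membered aromatic ring in place of 4-methyl-1H-imidazol-1-yl gives a 1.6-fold lower unbound fraction from compound 2 to compound 3 (0.20 log units; within the scatter). For the compounds shown here, measured from the group without the methyl, the same larger group gives a 2.3-fold lower unbound fraction from compound 1 to compound 3 (0.36 log units; beyond the scatter), the first step at this position to pass beyond the scatter. No measurement at hand accounts for this shift. The compounds shown leave open whether both aromatic rings of the larger group are needed for it, and how an amine or a carboxylic acid on this aromatic carbon would read.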